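A chloro-for-hydrogen step from compound 2 to compound 3

The compounds below may be only part of what the source reports. "The series", "measured", "known", "first", "only" and "open" are said of these compounds alone.

Measured so far:
compound 1 `COc1ccc(NC(=O)COC(=O)/C=C/c2ccc(O)c(O)c2)cc1`: 79100 nM
compound 2 `COc1ccc(/C=C/C(=O)OCC(=O)Nc2ccccc2)cc1OC`: > 200000 nM

In a functional assay on K562 cells (Homo sapiens) for cytotoxicity, read by MTT assay, with a stated time of 72 h (on this read-out lower numbers stand for stronger inhibition and higher numbers for weaker inhibition), compound 1 gives 79100 nM. Compound 2 gives only a limit of the assay, not a number, namely > 200000 nM. Compound 2 thus stands at the limit of > 200000 nM in this assay, at which 1 of the 2 values shown sits. Compound 3 `COc1ccc(/C=C/C(=O)OCC(=O)Nc2ccc(Cl)cc2)cc1OC` differs from compound 2 by chloro in place of hydrogen on an aromatic carbon. Going by the values given here, no measured pair shows this change, so in this assay the step is expected to be none beyond the scatter, in either direction. Compound 3 is expected to give 250000 nM, within 100000 nM to 600000 nM. The expected step is a step that the limit leaves unreadable from compound 2 to compound 3.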

Compound 3, half-maximal inhibitory concentration: 60200 nM
For compound 3 the middle estimate is 4.2-fold (0.62 log units) above the measured one, outside the stated range (below it).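

In this assay, going by these compounds alone, moving from phenyl to 4-chlorophenyl, with chloro on an aromatic carbon para to a large group, gives an at least 3.3-fold lower number from compound 2 to compound 3 (0.52 log units; beyond the scatter), the first step that can be read between compounds differing in one place. Compound 2 gives > 200000 nM, which is a limit of the assay and not a number. The step is therefore a lower bound, and it rests on that limit: the limit of > 200000 nM in this assay, at which 1 of the 3 values shown sits.

The compounds shown leave open whether bromo, a methyl or an amine at that carbon would give a similar step. They also leave open whether chloro would do the same on the core of compound 1.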